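A few compounds are considered here, and "the series" means these few. Any claim that something is new, unique, unknown or untested is made for them only; others in the source may bear on it.

Measured so far:
compound 1 `Nc1ccc(-c2cnc(C(=O)CCCCCCc3ccccc3)o2)cc1` — 90 nM
compound 2 `O=C(CCCCCCc1ccccc1)c1ncc(-c2nnn[nH]2)o1` — 63 nM

Going by the values given here, in an assay (Rattus norvegicus) for inhibition of Fatty-acid amide hydrolase 1 (Homo sapiens) (on this read-out lower numbers stand for stronger inhibition and higher numbers for weaker inhibition), compound 2 gives 63 nM, the lowest of the two numbers, though its only neighbour, compound 1, stands within the scatter of it. Compound 3 `CN1CCN(C(=O)c2cnc(C(=O)CCCCCCc3ccccc3)o2)CC1` is the next unmeasured member; it differs from compound 2 by (4-methylpiperazin-1-yl)carbonyl in place of 1H-tetrazol-5-yl on an aromatic carbon. Among the compounds with values here, the single measured step at this same position, a 1.4-fold lower number from compound 1 to compound 2 (0.15 log units; within the scatter), exchanged one group for another with no change beyond the scatter, which is the only bearing the data give on the new exchange. The expectation is therefore for no step beyond the scatter, with wide uncertainty. Compound 3 is expected at 120 nM, within 30 nM to 500 nM, an estimated step of a 1.9-fold higher number from compound 2 to compound 3 (0.28 log units; within the scatter).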

Compound 3, inhibition constant: 80 nM
Beside the measured number, compound 3's estimate is 1.5-fold (0.18 log units) above it; the range from low to high includes it.
By their numbers in this assay, from the lowest: compounds 2, 3 and 1 (each within the scatter of the next).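

In this assay the step of a 1.3-fold higher number from compound 2 to compound 3 (0.10 log units; within the scatter) and the step of a 1.1-fold lower number from compound 1 to compound 3 (0.05 log units; within the scatter) show that a third, larger group with a six-membered non-aromatic ring and 0 hydrogen-bond donors is accommodated next to the ring oxygen with no change beyond the scatter. Across these three compounds, the position therefore tolerates aromatic and non-aromatic groups alike. Nothing measured here explains this flat response.

Still open, as far as these compounds go, is whether a carboxylic acid or a bare hydrogen at this position would also stay within the scatter. Also open, from the compounds shown here alone, is whether the flat response would hold with a longer chain on the ketone side.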